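This account rests on a few compounds, and the source may have more. Where it says the series, first, only, none or still open, it means among the compounds named here.

Measured compounds:
- Compound 1, `Cc1ccccc1-c1nc(CN2CCC(C(=O)NCCCN3CCC(C)(C)CC3)CC2)c(C)o1`: 241 10^-6 cm/s
- Compound 2, `Cc1oc(-c2ccc(F)cc2)nc1CN1CCC(C(=O)NCCCN2C[C@H](C)C[C@H](C)C2)CC1`: "not determined" (no result reported)

Compound 1 was tested in a physicochemical assay for permeability, using PAMPA (on this read-out higher numbers stand for higher permeability and lower numbers for lower permeability), where compound 1 gives 241 10^-6 cm/s. Compound 2 carries a different group on the shared core, but in this assay compound 2 gives "not determined" (no result reported), so there is no single number to place it on. Compound 3, `Cc1cccc(C)c1-c1nc(CN2CCC(C(=O)NCCCN3C[C@H](C)C[C@H](C)C3)CC2)c(C)o1`, has not been measured in this assay. It differs from compound 2 in one place: 2,6-dimethylphenyl in place of 4-fluorophenyl on an aromatic carbon. Within the data shown here, with no number for compound 2, no step from compound 2 to compound 3 can be stated, neither its size nor its direction. Among the measured compounds shown here, what remains is the one measured compound, which shares the rest of the structure with compound 3 apart from the two ring substituents; in this assay compound 1 reads 241 10^-6 cm/s. On that basis the reading for compound 3 is expected to be 250 10^-6 cm/s, with a likely range from 100 10^-6 cm/s to 550 10^-6 cm/s.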

Compound 3, apparent permeability: 254 10^-6 cm/s
Estimate against measurement, compound 3: 1.0-fold (0.01 log units) below, within the range that was stated.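

In this assay, among these compounds, compound 2 has no single number, and no step from compound 2 to compound 3 can be read. As far as these compounds go, what 2,6-dimethylphenyl in place of 4-fluorophenyl does to this read-out stays open. No further data shown here bear on the result for compound 3.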